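A few compounds are considered here, and "the series" means these few. Any claim that something is new, unique, unknown or untested is made for them only; others in the source may bear on it.

Working notes on the series, read in a functional assay on DU-145 cells (Homo sapiens) for inhibition, read by trypan blue exclusion, with a stated time of 96 h; a lower number here means a stronger inhibitor of growth, a higher number a weaker inhibitor of growth. Compound 1 (`O=C(/C(=C\c1ccc(Br)cc1)Sc1ccc(Br)cc1)c1ccc(Br)cc1`) gives 1000 nM and compound 3 (`O=C(/C(=C\c1c[nH]c2ccccc12)Sc1ccc(Br)cc1)c1ccc(Br)cc1`) gives 1000 nM. The two sit level, with no change at the digits printed from compound 1 to compound 3 (within the scatter). Compound 2 (`COc1cc(/C=C(/Sc2ccc(Br)cc2)C(=O)c2ccc(Br)cc2)ccc1F`) gives 10000 nM, above both of them, and the gap to compound 3 is a 10-fold lower number from compound 2 to compound 3 (1.00 log units; beyond the scatter).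

The next compound to be read is compound 4 (`COc1ccc(/C=C(/Sc2ccc(Br)cc2)C(=O)c2ccc(Br)cc2)c(F)c1`), which changes the group on a double-bonded chain carbon bound to a double-bonded chain carbon: 2-fluoro-4-methoxyphenyl in place of 1H-indol-3-yl on a double-bonded chain carbon bound to a double-bonded chain carbon.

Within the data shown here, two measured steps bear on this change. Compound 2 is the nearest comparison, as it carries 4-fluoro-3-methoxyphenyl at the same place, and the move to it from compound 1 is a 10-fold higher number from compound 1 to compound 2 (1.00 log units; beyond the scatter). The move from compound 2 to the indole of compound 3 is the same gap in the opposite direction, so both steps are modest and beyond the scatter. Among the measured compounds shown here, no compound with 2-fluoro-4-methoxyphenyl has been measured yet, so the transfer from compound 2 is uncertain, and only part of that gap is assumed to carry over.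

A rise in the number is therefore expected, with an estimated size of a 5.0-fold higher number from compound 3 to compound 4 (0.70 log units; beyond the scatter). Compound 4 is expected at 5000 nM, with an estimated range from 1500 nM to 15000 nM.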

Compound 4, concentration for 50% growth inhibition: 20000 nM
Compound 4: middle estimate off by 4.0-fold (0.60 log units), on the low side; measured number outside the range, above it.
By their numbers in this assay, from the lowest: compounds 1 and 3 (each within the scatter of the next); then compounds 2 and 4 (each within the scatter of the next).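

In this assay the group 2-fluoro-4-methoxyphenyl gives a 20-fold higher number from compound 3 to compound 4 (1.30 log units; beyond the scatter) and a 20-fold higher number from compound 1 to compound 4 (1.30 log units; beyond the scatter) on the double-bonded chain carbon, so the high number seen with 4-fluoro-3-methoxyphenyl is not confined to that one group. The two fluoro-methoxy groups read alike, with a 2.0-fold higher number from compound 2 to compound 4 (0.30 log units; within the scatter) as the step between them, and among the four compounds shown both stand apart from 1H-indol-3-yl and 4-bromophenyl, with no compound going against that split. Nothing on hand accounts for this split.

From the compounds shown here alone, whether the split follows the methoxy, the fluorine or the two together stays open, and 4-methoxyphenyl and 4-fluorophenyl on the same carbon would separate them. Also open, going by these compounds, is whether any other group at this place, such as 4-aminophenyl or a pyridine ring, goes lower than compound 1 and compound 3, and whether the split holds when the two remaining 4-bromophenyl groups of the shared core change.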